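This account rests on a few compounds, and the source may have more. Where it says the series, first, only, none or still open, it means among the compounds named here.

For the measured compounds named here, compound 1 `C=CCn1c(=O)c2[nH]cnc2n(CCC)c1=O` gives 1700 nM in an assay on Cerebral cortex for binding affinity to adenosine receptor A1 (Cavia porcellus), read by radioligand binding (a higher number here means a weaker inhibitor, a lower number a stronger inhibitor), the higher of the two numbers measured so far. Compound 2 `C=CCCn1c(=O)c2[nH]cnc2n(CCC)c1=O` gives 60 nM, and a 28-fold lower number from compound 1 to compound 2 (1.45 log units; beyond the scatter) shows that a longer chain at this position is well tolerated. Compound 3 `CCCn1c(=O)n(CCCN(C)C)c(=O)c2[nH]cnc21` differs from compound 1 by 2-(dimethylamino)ethyl in place of vinyl on a saturated chain carbon bound to an aromatic nitrogen, again a lengthening at the same place, though the entering group carries a nitrogen rather than carbon alone. Going by the values given here, only that one measured step bears on the change, and the entering group itself is unmeasured, so a smaller step is expected: a 4.9-fold lower number from compound 1 to compound 3 (0.69 log units; beyond the scatter). Compound 3 is estimated at 350 nM, within 70 nM to 1700 nM.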

Compound 3, inhibition constant: 43200 nM
Estimate against measurement, compound 3: 120-fold (2.09 log units) below, outside the stated range (above it).
By their numbers in this assay, from the lowest: compound 2; then compound 1; then compound 3.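

Chain length alone does not decide the result at this position. With a 3-(dimethylamino)propyl chain, this assay shows a 25-fold higher number from compound 1 to compound 3 (1.41 log units; beyond the scatter), and a 720-fold higher number from compound 2 to compound 3 (2.86 log units; beyond the scatter), so the gain seen with the longer all-carbon chain of compound 2 does not extend to this nitrogen-bearing chain. Nothing available accounts for this loss.

On these data alone, whether a longer plain carbon chain would keep the affinity of compound 2 remains open. So does whether a primary amine, an ether or a carboxylic acid at the chain end would behave like the dimethylamino group.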